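A Second Chloro Group on a Growth-Inhibiting Core

The source may report more compounds than this note shows. Statements on the series, on what has been measured and on what is new or still open speak of the compounds shown alone.

Measured compounds:
Compound 1, `ClCc1ccccc1Cn1cnc2c(Cl)nc(Cl)nc21`: 2950 nM
Compound 2, `ClCc1ccccc1Cn1cnc2c(Cl)ncnc21`: 33100 nM
Compound 3, `ClCc1cccc(Cn2cnc3c(Cl)ncnc32)c1`: 13500 nM

All three were tested in a functional assay on KM12 cells (Homo sapiens) for cytotoxicity, read by sulforhodamine B assay, with a stated time of 48 h; on this read-out higher numbers stand for weaker inhibition of growth and lower numbers for stronger inhibition of growth. Compound 2 and compound 3 share the same atoms joined differently; the difference between the two cores is not broken down here. Compound 1 arises from compound 2 by one change, (chloro in place of hydrogen on an aromatic carbon), and this gave an 11-fold lower number from compound 2 to compound 1 (1.05 log units; beyond the scatter). The unmeasured compound 4, `ClCc1cccc(Cn2cnc3c(Cl)nc(Cl)nc32)c1`, arises from compound 3 by the same change, (chloro in place of hydrogen on an aromatic carbon). Because the earlier step of an 11-fold lower number from compound 2 to compound 1 (1.05 log units; beyond the scatter) was large and beyond the scatter, a step of comparable size is expected here, so that from compound 3 to compound 4 the expected change is an 11-fold lower number from compound 3 to compound 4 (1.05 log units; beyond the scatter). For compound 4 the estimated result in this assay is 1200 nM, expected to lie between 450 nM and 4000 nM.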

Compound 4, concentration for total growth inhibition: 3800 nM
The estimate for compound 4 lay 3.2-fold (0.50 log units) below the measured number; low and high end bracket the measured number.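

In this assay, putting chloro in place of hydrogen on the aromatic carbon lowers the number again, with a 3.6-fold lower number from compound 3 to compound 4 (0.55 log units; beyond the scatter). The direction of the change carries over from one core to the other, but its size does not: the same change on two cores in this assay, an 11-fold lower number (1.05 log units; beyond the scatter) from compound 2 to compound 1 and a 3.6-fold lower number (0.55 log units; beyond the scatter) from compound 3 to compound 4, 3.2-fold (0.50 log units) apart, beyond the scatter of two such steps

These two pairs show that the size of the step can differ between cores, but they do not show why, or how the change would behave on any further core. Going by these compounds, it remains open whether an amine or a methoxy group on the same carbon, between two ring nitrogen atoms, would also lower the number. On these data alone, it also remains open how far such a group's effect would differ between the two cores.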